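The source may hold more compounds than are shown below. What is called first, only, known or untested is meant among the compounds shown, and "the series" means these compounds.

Compounds measured so far:
Compound 1, `CC(C)N(Cc1cccc(OCCCCCC(=O)O)c1)C(=O)c1ccc(-c2cccc(OCc3ccccc3)c2)cc1` – in an ADME assay on HepG2 cells (Homo sapiens) for cytotoxicity, read by CellTiter-Glo and resazurin assay, with a stated time of 72 h (a higher number here means that more compound is needed for the effect, a lower number that less compound is needed), compound 1 gives > 26000 nM, a limit of the assay and not a number.
Compound 2, `CC(C)N(Cc1cccc(OCCCCCC(=O)O)c1)C(=O)c1ccc(-c2ccc3c(c2)OCCO3)cc1` – in this assay compound 2 gives > 21900 nM, again only a limit.
Compound 3, `CCOC(=O)CCCCCOc1cccc(CN(C(=O)c2ccc(-c3cccc(OCc4ccccc4)c3)cc2)C(C)C)c1` – in this assay compound 3 gives > 26000 nM, likewise only a limit.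

Compound 3 therefore stands nowhere definite on the numbers shown: all three values in this assay are limits, two of them at the limit of > 26000 nM in this assay, at which 2 of the 3 values shown sit, and one at the limit of > 21900 nM in this assay, at which 1 of the 3 values shown sits. For the measured compounds named here, the one measured step that differs in a single place, a step that the two limits leave unreadable from compound 1 to compound 3, is unreadable for the same reason.

The unmeasured compound 4, `CCOC(=O)CCCCCOc1cccc(CN(C(=O)c2ccc(-c3cccc(CC(=O)O)c3)cc2)C(C)C)c1`, differs from compound 3 by carboxymethyl in place of benzyloxy on an aromatic carbon. Going by the values given here, that step bears no relation to any readable measured step, since the only comparison available, from compound 1 to compound 3, is caught between two limits. Among the compounds with values here, what the three limits do show is that none of the measured compounds reached a half-maximal effect within the tested range.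

Compound 4 is accordingly expected to sit near the same limit, with an estimate of 26000 nM ranging from 10000 nM to 60000 nM, so that the expected step of a number no higher from compound 3 to compound 4 (the limit leaves the size open) is no larger than the scatter, in no stated direction.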

Compound 4, half-maximal effective concentration: > 26000 nM
Compound 4 was reported as a limit; the forecaster's own chance of this, stated with the estimate: 75%; the middle value sits exactly at the limit.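

In this assay compound 4 gives > 26000 nM, a limit of the assay and not a number, so no step can be read between compound 3 and compound 4, which also carries only a limit. The compounds shown leave open where any of them would reach a half-maximal effect, and whether carboxymethyl in place of benzyloxy alters it.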